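This account rests on a few compounds, and the source may have more. Where it says the series, first, only, none or still open, it means among the compounds named here.

Measured so far in a functional assay on MCF7 cells (Homo sapiens) for inhibition, read by MTT assay, with a stated time of 48 h; on this read-out higher numbers stand for weaker inhibition and lower numbers for stronger inhibition:

- compound 1, `Brc1ccccc1CSc1nnc(-c2ccncc2)n1-c1ccccc1`, gives 16100 nM
- compound 2, `Brc1cccc(CSc2nnc(-c3ccncc3)n2-c2ccccc2)c1`, gives 10000 nM
- compound 3, `O=[N+]([O-])c1cccc(CSc2nnc(-c3ccncc3)n2-c2ccccc2)c1`, gives 18300 nM

Compound 1 stands second highest of these three numbers. Its nearest neighbour is compound 3, reached by a 1.1-fold higher number from compound 1 to compound 3 (0.06 log units; within the scatter), and its furthest is compound 2, reached by a 1.6-fold lower number from compound 1 to compound 2 (0.21 log units; within the scatter); both of these steps stay within the scatter, so the three compounds cannot be told apart on this read-out.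

Compound 4, `O=[N+]([O-])c1ccc(CSc2nnc(-c3ccncc3)n2-c2ccccc2)cc1`, has not yet been measured. Relative to compound 1 the change is 4-nitrophenyl in place of 2-bromophenyl on a saturated chain carbon bound to a sulfur. For the measured compounds named here, three measured steps bear on it. Moving the bromine to another position on the ring gave a 1.6-fold lower number from compound 1 to compound 2 (0.21 log units; within the scatter). Replacing the bromophenyl group with a nitrophenyl group at a different ring position gave a 1.1-fold higher number from compound 1 to compound 3 (0.06 log units; within the scatter). Exchanging bromo for nitro on the same ring position gave a 1.8-fold higher number from compound 2 to compound 3 (0.26 log units; within the scatter). None of these moved the number beyond the scatter, so for compound 4 a step of a 1.2-fold lower number from compound 1 to compound 4 (0.06 log units; within the scatter) is expected, that is, no change beyond the scatter in either direction.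

Compound 4 is therefore estimated at 14000 nM in this assay, with a range from 6000 nM to 35000 nM.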

Compound 4, half-maximal inhibitory concentration: 22800 nM
Compound 4: the middle estimate sits 1.6-fold (0.21 log units) below what was measured; the measured number falls inside the stated range.
By their numbers in this assay, from the lowest: compounds 2, 1, 3 and 4 (each within the scatter of the next, the first and the last beyond it).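

For the compounds shown here, the new information is a 2.3-fold higher number from compound 2 to compound 4 (0.36 log units; beyond the scatter) in this assay, the first step in this set to pass the scatter, which shows that changing the aromatic group on the saturated chain carbon bound to a sulfur can shift the number, if only modestly. The other two steps remain small: 4-nitrophenyl in place of 3-nitrophenyl gives a 1.2-fold higher number from compound 3 to compound 4 (0.10 log units; within the scatter), and 4-nitrophenyl in place of 2-bromophenyl gives a 1.4-fold higher number from compound 1 to compound 4 (0.15 log units; within the scatter), so compound 4 cannot be told apart from compound 1 or compound 3, and only its pairing with compound 2 stands out. No measurement here explains that single larger step.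

Compound 2 and compound 4 differ in both the ring group and its numbered ring position, so these compounds leave open which of those two differences carries the step. Every group shown at this place is also a phenyl ring bearing bromo or nitro, so it remains open how the number would respond to an amine or a carboxylic acid on that ring, or to a longer chain on the sulfur.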